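Aryl Swap on a Piperazine Amide: Expected Anticonvulsant Dose

The compounds below may be only part of what the source reports. "The series", "measured", "known", "first", "only" and "open" are said of these compounds alone.

Measured compounds:
compound 1 `CC1CC(=O)N(CC(=O)N2CCN(c3ccc(Cl)cc3)CC2)C1=O` — 100 mg/kg
compound 2 `CCC1(C)CC(=O)N(CC(=O)N2CCN(c3ccccc3C)CC2)C1=O` — 100 mg/kg

In a functional assay on the whole organism (strain CD1) with Mus musculus as the target, in the maximal electroshock model, with a stated time of 0.5 h (on this read-out higher numbers stand for an effect only at larger amounts of compound and lower numbers for an effect already at smaller amounts), compound 1 gives 100 mg/kg. Compound 2, which shares the core and differs in several places, gives 100 mg/kg in this assay, so the two values stand level at the digits reported, within the scatter of repeated measurements. On the numbers shown, compound 1 therefore sits at the same dose as its only measured neighbour, and nothing in the pair points to either a stronger or a weaker effect.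

Compound 3 `Cc1cccc(N2CCN(C(=O)CN3C(=O)CC(C)C3=O)CC2)c1` has not yet been measured in this assay. It differs from compound 1 in one place: 3-methylphenyl in place of 4-chlorophenyl on an amine nitrogen in a ring. Going by the values given here, no measured pair shows the effect of this exchange on the same core, so the only guide is that the two measured compounds, with different aryl groups on the amine nitrogen in a ring, both gave the same dose.

For compound 3 the step of no change at the digits printed from compound 1 to compound 3 (within the scatter) is expected to be none beyond the scatter. Compound 3 is estimated at 100 mg/kg in this assay, with a range from 30 mg/kg to 300 mg/kg.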

Compound 3, minimum effective dose: 300 mg/kg
The estimate for compound 3 lay 3.0-fold (0.48 log units) below the measured number; the measured number falls inside the stated range.
By their numbers in this assay, from the lowest: compounds 1 and 2 (each within the scatter of the next); then compound 3.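

In this assay, 3-methylphenyl in place of 4-chlorophenyl on an amine nitrogen in a ring gives a 3.0-fold higher number from compound 1 to compound 3 (0.48 log units; beyond the scatter), so on the shared core this position is not indifferent to which aryl group it carries. Going by these compounds alone, compound 1 and compound 2 differ in several places, and their matching values said nothing about any single change; this step is the first read on one exchange alone, and it runs toward an effect only at larger amounts of compound. The two aryl groups have the same count of heavy atoms and each holds one six-membered aromatic ring of carbon only, yet no measurement at hand explains the step.

Going by these compounds, whether the step follows the loss of chlorine, the gain of methyl or the different place of the substituent on the aryl ring stays open, as this single exchange changes all three at once. The compounds shown also do not tell how a plain phenyl or a methoxyphenyl on the same nitrogen would stand in this assay.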